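A few compounds are considered here, and "the series" means these few. Any claim that something is new, unique, unknown or untested is made for them only; others in the source may bear on it.

Series in a functional assay on U-87MG ATCC cells (Homo sapiens) for cytotoxicity, read by MTT assay, with a stated time of 48 h; on this read-out lower numbers stand for stronger inhibition and higher numbers for weaker inhibition:
- compound 1 `CC(=NNC(=S)Nc1ccccc1F)c1ccccn1`: 5 nM
- compound 2 `CC(=NNC(=S)Nc1cccc(F)c1)c1ccccn1`: 18 nM
- compound 3 `C/C(=N/NC(=S)Nc1ccccc1F)c1ccccn1`: 5 nM

Compound 1 shares the lowest number of the three with compound 3, while compound 2 stands clearly higher at 18 nM.

Next is compound 4 `CC(=NNC(=S)Nc1ccccc1[N+](=O)[O-])c1ccccn1`, which has nitro in place of fluoro on an aromatic carbon, ortho to a large group: nitro in place of fluoro on an aromatic carbon.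

Among the compounds with values here, the only measured step, no change at the digits printed from compound 1 to compound 3 (within the scatter), reflects (the fact that one of compounds 1 and 3 is drawn with a defined configuration and the other without, at the place where they differ). It leaves the fluoro untouched and so gives no size for this exchange. Within the data shown here, no measured compound carries any group other than fluoro on this ring, so the expectation is loose. The one spread available is the gap between compound 1 at 5 nM and compound 2 at 18 nM, which suggests that a moderate move is plausible. With compound 1 already at the low end of the series, any move in this assay is expected to be towards a higher number.

The step expected is a 3.0-fold higher number from compound 1 to compound 4 (0.48 log units; beyond the scatter).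

For compound 4 the estimated value is 15 nM, with an expected range of 3 nM to 80 nM.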

Compound 4, half-maximal inhibitory concentration: 4.3 nM
Compound 4: middle estimate off by 3.5-fold (0.54 log units), on the high side; the range from low to high includes it.
By their numbers in this assay, from the lowest: compounds 4, 1 and 3 (each within the scatter of the next); then compound 2.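

In this assay, the exchange gives a 1.2-fold lower number from compound 1 to compound 4 (0.07 log units; within the scatter): with 3 heavy atoms and 2 hydrogen-bond acceptors entering where 1 heavy atom leaves, on an aromatic carbon, ortho to a large group, the number does not move outside the scatter. Within the data shown here, the earlier compounds carried only fluoro on this ring, so this is the first sign that this place accepts a group other than fluoro, while compound 2, with fluoro elsewhere on the ring, stands clearly higher at 18 nM. Nothing available on these compounds speaks to why nitro and fluoro read alike here.

Going by these compounds, whether an amine, a carboxylic acid or a longer chain at this place would hold the number remains open. Also open, on these data alone, is whether nitro elsewhere on the ring would give a higher number, as fluoro does in compound 2.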